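This account rests on a few compounds, and the source may have more. Where it says the series, first, only, none or still open, it means among the compounds named here.

In a functional assay on K562 cells (Homo sapiens) for cytotoxicity, read by MTT assay (on this read-out lower numbers stand for stronger inhibition and higher numbers for weaker inhibition), compound 1 `COc1ccc(/C=C/C(=O)c2ccc(OC)c3c2OC(C)(C)C=C3)cc1O` gives 630 nM. Compound 2 `C#CCOc1cc(/C=C/C(=O)c2ccc(OC)c3c2OC(C)(C)C=C3)ccc1OC` gives > 10000 nM, which is a limit of the assay and not a number. Compound 2 therefore has no exact place on the scale, and any comparison with it stays loose.

Among the compounds with values here, only one measured step bears on what follows, and it is large: an at least 15-fold higher number from compound 1 to compound 2 (1.20 log units; beyond the scatter), with propargyl in place of hydrogen on an oxygen on an aromatic ring.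

Compound 3 `C=CCOc1cc(/C=C/C(=O)c2ccc(OC)c3c2OC(C)(C)C=C3)ccc1OC` differs from compound 2 at the far end of that same group: vinyl in place of ethynyl on a saturated chain carbon bound to an oxygen on an aromatic ring. In words, this is vinyl in place of ethynyl on a saturated chain carbon bound to an oxygen on an aromatic ring, so propargyloxy becomes allyloxy. Within the data shown here, no measured step covers this exact change. However, compound 3 also lacks the hydrogen that was replaced in going to compound 2, and that replacement came with an at least 15-fold higher number from compound 1 to compound 2 (1.20 log units; beyond the scatter). In this assay, compound 3 is therefore expected to stay close to compound 2, with no clear move back towards compound 1.

The expected change is a number no higher from compound 2 to compound 3 (the limit leaves the size open).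

For compound 3, the estimated value is 10000 nM, with an expected range of 3000 nM to 30000 nM.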

Compound 3, half-maximal inhibitory concentration: > 10000 nM
Compound 3: a limit, no number (the forecaster's own chance of this, stated with the estimate: 60%); the middle value lies on the limit itself.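

In this assay, allyl in place of hydrogen on an oxygen on an aromatic ring brings an at least 15-fold higher number from compound 1 to compound 3 (1.20 log units; beyond the scatter). Compound 2 already showed a large step at this oxygen, and compound 3 now shows that the step does not depend on the triple bond of propargyl, since a group ending in a double bond goes the same way. Compound 3 has a limit of the assay and not a number, as does compound 2, so the step between them cannot be read and neither compound can be placed above the other: the limit of > 10000 nM in this assay, at which 2 of the 3 values shown sit.

What the two capped oxygens share is a three-carbon chain in place of the hydrogen, but these compounds alone cannot tell whether any group on this oxygen brings the same large step or only groups of this kind. An ethyl group, or a chain ending in an amine or a carboxylic acid, on the same oxygen would test this, and would show whether the number can stay near that of compound 1 at 630 nM once the hydrogen is gone.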